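This account rests on a few compounds, and the source may have more. Where it says the series, first, only, none or still open, it means among the compounds named here.

Measured so far:
Compound 1, `CN(C)c1ncnc2c1ncn2C1CCCC1`: 27%
Compound 2, `CCN(CC)c1ncnc2c1ncn2CC1CC1`: 0%

Both numbers come from a functional assay on the whole organism for inhibition, with Rattus norvegicus as the target, at a dose of 25 mg/kg by the intraperitoneal route; on this read-out lower numbers stand for less inhibition and higher numbers for more inhibition at the one dose given (going by the name of the read-out). Compound 2 stands at the lower of the two: compound 1 sits a number higher that lies beyond the usual scatter of this measurement, while compound 2 shows no inhibition at all at the dose given.

The next compound, compound 3, `c1nc(NCC2CC2)c2ncn(CC3CC3)c2n1`, differs from compound 2 in one place: (cyclopropylmethyl)amino in place of diethylamino on an aromatic carbon. Within the data shown here, no pair of measured compounds shares this change, so no measured step shows what it does. Among the measured compounds shown here, the two measured values tell only that closely related compounds can sit at zero or at a modest number.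

For compound 3 the expectation is a small step from the zero of compound 2, with a number 10 percentage points higher from compound 2 to compound 3 (within the scatter), which stays within the scatter. The estimate for compound 3 is 10%, in a range from 0% to 32%.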

Compound 3, a percentage reported as inhibition, in the whole organism at one dose (the size of the read-out at that dose, not a potency): 28%
Beside the measured number, compound 3's estimate is 18 percentage points below it; low and high end bracket the measured number.
By their numbers in this assay, from the lowest: compound 2; then compounds 1 and 3 (each within the scatter of the next).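

In this assay, putting (cyclopropylmethyl)amino in place of diethylamino on this aromatic carbon gives a number 28 percentage points higher from compound 2 to compound 3 (beyond the scatter), so the group at this position can decide whether any inhibition appears at the one dose given. The two groups have the same count of heavy atoms, but the entering group brings a three-membered ring of carbon and a hydrogen-bond donor that diethylamino lacks. Nothing shown explains why the number changes.

This single step cannot separate the contribution of the ring from that of the amine hydrogen, since both change together. An ethylamino group at this place would keep the hydrogen without the ring, while a cyclobutylmethylamino group would show whether the size of the ring matters.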